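The source may hold more compounds than are shown below. What is called first, only, known or untested is meant among the compounds shown, and "the series" means these compounds.

Working notes on the series. Three compounds carry a value in an ADME assay on HEL cells (Homo sapiens) for cytotoxicity, with a stated time of 3 days; on this read-out higher numbers stand for lower toxicity in this test and lower numbers for higher toxicity in this test: compound 1 `Cc1cc(C#N)cn2c(CSCCc3ccccc3)cnc12` gives 20 ug/mL, compound 2 `Cc1cc(Sc2ccc(O)cc2)cn2c(CSCCc3ccccc3)cnc12` gives 4 ug/mL and compound 3 `Cc1cc(-c2ccco2)c2ncc(CSCCc3ccccc3)n2c1` gives 100 ug/mL. Compound 3 has the highest of the three numbers; nearest is compound 1 and furthest is compound 2. Within the data shown here, the only step at this position is a 5.0-fold lower number from compound 1 to compound 2 (0.70 log units; beyond the scatter). Compound 4 `Cc1cc(-n2ccc3ccccc32)c2ncc(CSCCc3ccccc3)n2c1` differs from compound 3 by 1H-indol-1-yl in place of furan-2-yl on an aromatic carbon. Among the measured compounds shown here, no measured step covers this exchange; the single step from compound 1 to compound 2 describes a different change at the same place, so it gives little guidance. For compound 4 a modest lowering is expected, a 2.0-fold lower number from compound 3 to compound 4 (0.30 log units; within the scatter), giving an estimated 50 ug/mL with a range from 20 ug/mL to 100 ug/mL.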

Compound 4, minimum cytotoxic concentration: 100 ug/mL
Estimate against measurement, compound 4: 2.0-fold (0.30 log units) below; measured number inside the range.
By their numbers in this assay, from the lowest: compound 2; then compound 1; then compounds 3 and 4 (each within the scatter of the next).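

Replacing furan-2-yl with 1H-indol-1-yl on this aromatic carbon gives no change at the digits printed from compound 3 to compound 4 (within the scatter) in this assay and stays at the high end of the numbers in the series. The entering group brings an additional six-membered aromatic ring of carbon only, and at this place that added ring leaves the read-out within the scatter. No available evidence bears on this result. Open, as far as these compounds go, is what an amine, a carboxylic acid or a longer chain on this aromatic carbon would give, and whether the read-out would hold with any of them.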